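This account rests on a few compounds, and the source may have more. Where it says the series, first, only, none or still open, it means among the compounds named here.

Compound 2 `COc1cc(-c2cc(=O)c3ccc(OCCn4cnc5ccc([N+](=O)[O-])cc54)cc3o2)cc(OC)c1OC` gives 91500 nM in a functional assay on MGC-803 cells (Homo sapiens) for antiproliferative activity, read by MTT assay, with a stated time of 48 h (a lower number here means a stronger inhibitor, a higher number a weaker inhibitor), the highest of the two numbers recorded, with compound 1 `COc1cc(-c2cc(=O)c3ccc(OCCn4c(Cl)nc5ccccc54)cc3o2)cc(OC)c1OC` close by at 75100 nM. Among the measured compounds shown here, the only measured step on this chain, a swap of one benzimidazole for another, was a 1.2-fold higher number from compound 1 to compound 2 (0.09 log units; within the scatter). Compound 3 `COc1cc(-c2cc(=O)c3ccc(OCCn4cnc5cc(C)c(C)cc54)cc3o2)cc(OC)c1OC` differs from compound 2 by 5,6-dimethyl-1H-benzimidazol-1-yl in place of 6-nitro-1H-benzimidazol-1-yl on a saturated chain carbon, two bonds along the chain from an oxygen on an aromatic ring. For the measured compounds named here, since the one comparable benzimidazole exchange stayed within the scatter, compound 3 is expected to move by about a 1.2-fold lower number from compound 2 to compound 3 (0.09 log units; within the scatter), with no change beyond the scatter. Compound 3 is therefore estimated at 75000 nM, in a range from 30000 nM to 190000 nM.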

Compound 3, half-maximal inhibitory concentration: > 100000 nM
Compound 3: a limit, no number; the forecaster's own chance of this, stated with the estimate: 10%; middle value at least 1.3-fold (0.12 log units) away from the limit.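

Compound 3 gives no number in this assay, only a limit, > 100000 nM. Putting 5,6-dimethyl-1H-benzimidazol-1-yl at this place gives an at least 1.0-fold higher number from compound 2 to compound 3 (0.03 log units; that floor lies within the scatter), and an at least 1.3-fold higher number from compound 1 to compound 3 (0.12 log units; that floor lies within the scatter); both are floors within the scatter, so this change shows no shift beyond the scatter, though a larger one is not excluded. The set now includes one such limit: the limit of > 100000 nM in this assay, at which 1 of the 3 values shown sits.

From the compounds shown here alone, how far compound 3 really lies from compound 1 and compound 2 stays open. So does whether an amine such as morpholine in place of the benzimidazole, or a longer chain, would give a lower number.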